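Swapping Benzyl for Benzoyl: Expected Tolerance in HEL Cells

This account rests on a few compounds, and the source may have more. Where it says the series, first, only, none or still open, it means among the compounds named here.

Compound 1 `CCC1(Cc2ccccc2)OS(=O)(=O)C=C1OCc1ccc(F)cc1`: in an ADME assay on HEL cells (Homo sapiens) for cytotoxicity, with a stated time of 3 days (a lower number here means that less compound is tolerated, a higher number that more compound is tolerated), compound 1 gives > 50000 nM, which is a limit of the assay.
Compound 2 `CCC1(Cc2ccccc2)OS(=O)(=O)C=C1OCc1ccccc1`: in this assay compound 2 gives 200000 nM.

In this assay compound 2 holds the only number shown; the further value shown, that of compound 1, is a limit. The step that the limit leaves unreadable from compound 1 to compound 2, hydrogen in place of fluoro on an aromatic carbon, cannot be sized, as the limit of > 50000 nM in this assay, at which 1 of the 2 values shown sits, shows. Compound 3 `CCC1(Cc2ccccc2)OS(=O)(=O)C=C1OC(=O)c1ccccc1` differs from compound 2 by benzoyl in place of benzyl on an oxygen on an unsaturated carbon. Going by the values given here, no measured step touches this place; the single measured step sits elsewhere in the molecule and is itself unreadable, so the measured steps give no direction for this change. The step that is therefore expected is a 1.3-fold lower number from compound 2 to compound 3 (0.12 log units; within the scatter), which is not beyond the scatter. Compound 3 is estimated at 150000 nM in this assay, with a range from 50000 nM to 300000 nM.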

Compound 3, half-maximal cytotoxic concentration: > 200000 nM
Compound 3 ended at the assay's limit; the forecaster's own chance of this, stated with the estimate: 40%; middle value at least 1.3-fold (0.12 log units) from the limit.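

In this assay compound 3 gives > 200000 nM, which is a limit of the assay. Benzoyl in place of benzyl on an oxygen on an unsaturated carbon brings a number no lower from compound 2 to compound 3 (the limit leaves the size open), so this position now has a measured direction, which the earlier compounds could not give. The step between compound 1 and compound 3 cannot be read, and the true value of compound 3 stays unknown, as the size of its step from compound 2 does: the limit of > 200000 nM in this assay, at which 1 of the 3 values shown sits.

The compounds shown leave open how far the number rises with this change, if it rises at all beyond the limit. They also leave open whether a smaller acyl group such as acetyl, or an aminoethyl chain, on this oxygen would keep the number as high.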